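Aryl halogen change from compound 1 to compound 3

This account rests on a few compounds, and the source may have more. Where it says the series, first, only, none or still open, it means among the compounds named here.

Measured so far in a functional assay on PC-3 cells (Homo sapiens) for antiproliferative activity, read by MTT assay, with a stated time of 72 h; a higher number here means a weaker inhibitor, a lower number a stronger inhibitor:
- compound 1, `O=C(COc1ccc(C(=O)/C=C/c2cccc(Cl)c2)cc1)N[C@H]1CCOC1=O`: 4990 nM
- compound 2, `O=C(CNc1cccc(Cl)c1)N[C@H]1CCOC1=O`: reported only as a limit, > 64000 nM

Within the data shown here, compound 1 is the only compound with a number in this assay; the other result is a limit. Compound 2 sits at the limit of > 64000 nM in this assay, at which 1 of the 2 values shown sits. Among the measured compounds shown here, the two share no single-point change, so no step is drawn between them and nothing beyond their two results is read from the pair.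

Compound 3, `O=C(COc1ccc(C(=O)/C=C/c2ccc(Br)cc2)cc1)N[C@H]1CCOC1=O`, has not yet been measured. Its difference from compound 1: 4-bromophenyl in place of 3-chlorophenyl on a double-bonded chain carbon bound to a double-bonded chain carbon. The change swaps one halogenated phenyl for another at the same place on the chain, with no change in donor or acceptor count. For the measured compounds named here, no measured pair shows what such a swap does here. The expected step from compound 1 to compound 3 in this assay, a 1.1-fold lower number from compound 1 to compound 3 (0.04 log units; within the scatter), is estimated to be small, within the usual scatter, with no set direction. Compound 3 is thus expected to give about 4500 nM, between 1500 nM and 13000 nM.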

Compound 3, half-maximal inhibitory concentration: > 64000 nM
Compound 3 was reported as a limit; the forecaster's own chance of this, stated with the estimate: 5%; middle value at least 14-fold (1.15 log units) from the limit.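

The place on a double-bonded chain carbon bound to a double-bonded chain carbon does not accept every halogenated phenyl alike: in this assay, 4-bromophenyl in place of 3-chlorophenyl gives an at least 12-fold higher number from compound 1 to compound 3 (1.10 log units; beyond the scatter). The heavy-atom, hydrogen-bond donor and acceptor counts and the net charge of the two groups are the same, so these counts do not separate compound 1 from compound 3. The value of compound 3, > 64000 nM, is a limit and not a number, and the step therefore gives only a minimum size, with most of the values shown now at that limit: the limit of > 64000 nM in this assay, at which 2 of the 3 values shown sit.

The swap changes the halogen and its location on the phenyl together, and the compounds shown do not tell which of the two goes with the loss. Also open, as far as these compounds go, is how this place responds to a plain phenyl, or to a phenyl carrying an amine or a carboxylic acid.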